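Removing a Methyl Group from a Diaryl Urea

The source may report more compounds than this note shows. Statements on the series, on what has been measured and on what is new or still open speak of the compounds shown alone.

Three diaryl ureas have been tested in a functional assay on cells (Homo sapiens) for antiproliferative activity, read by sulforhodamine B assay, with a stated time of 5 days; on this read-out higher numbers stand for weaker inhibition and lower numbers for stronger inhibition. Compound 1 `COc1cc(NC(=O)Nc2cc(C(F)(F)F)cc(C(F)(F)F)c2)ccc1C` gives 1800 nM, compound 2 `COc1cc(NC(=O)Nc2ccc(Cl)c(Cl)c2)ccc1C` gives 800 nM, and compound 3 `Cc1ccc(NC(=O)Nc2ccc(Cl)c(Cl)c2)cc1O` gives 7500 nM. Compound 1 and compound 2 carry different right-hand rings; the difference between the two cores is not broken down here. Compound 3 arises from compound 2 by a single change, (hydrogen in place of methyl on an oxygen on an aromatic ring), and that step gave a 9.4-fold higher number from compound 2 to compound 3 (0.97 log units; beyond the scatter). Compound 4 `Cc1ccc(NC(=O)Nc2cc(C(F)(F)F)cc(C(F)(F)F)c2)cc1O` is not yet measured; it arises from compound 1 by the same change at the same kind of place, (hydrogen in place of methyl on an oxygen on an aromatic ring). For the measured compounds named here, the expectation for compound 4 rests on the one step already seen in this assay, a 9.4-fold higher number from compound 2 to compound 3 (0.97 log units; beyond the scatter). Compound 4 is therefore expected to weaken by about an 8.3-fold higher number from compound 1 to compound 4 (0.92 log units; beyond the scatter). The estimate for compound 4 in this assay is 15000 nM, likely between 5000 nM and 45000 nM.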

Compound 4, half-maximal inhibitory concentration: 2800 nM
Beside the measured number, compound 4's estimate is 5.4-fold (0.73 log units) above it, and the stated range ends above it.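

In this assay, going from methoxy to hydroxy gives a 1.6-fold higher number from compound 1 to compound 4 (0.19 log units; within the scatter), so on this core the change cannot be told apart from the usual scatter of repeated measurements. The size of the step did not carry over from one core to the other: the same change on two cores in this assay, a 9.4-fold higher number (0.97 log units; beyond the scatter) from compound 2 to compound 3 and a 1.6-fold higher number (0.19 log units; within the scatter) from compound 1 to compound 4, 6.0-fold (0.78 log units) apart, beyond the scatter of two such steps

A large step on one core therefore cannot be assumed on another in this series, but two pairs do not show why the cores differ or how other cores would respond.

The compounds shown leave open how an amine or a longer chain such as ethoxy would fare at this oxygen-bearing place on either core. They also leave open which right-hand rings behave like that of compound 1 and which like that of compound 2.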